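This account rests on a few compounds, and the source may have more. Where it says the series, first, only, none or still open, it means among the compounds named here.

Measured in a physicochemical assay for solubility, using the shake flask method, in phosphate buffer, with a stated time of 24 h, at pH 7.4; a lower number here means a less soluble compound, a higher number a more soluble compound:

- Compound 1 `CC(Sc1nc2c(cnn2C)c(=O)n1-c1ccccc1)c1ccccn1`: 20000 nM
- Compound 2 `COc1cccc(C(C)Sc2nc3c(cnn3C)c(=O)n2-c2ccccc2)c1`: < 2000 nM, a limit of the assay
- Compound 3 `CC(Sc1nc2c(cnn2C)c(=O)n1-c1ccccc1)c1cccnc1`: 209000 nM

Compound 3 stands highest of the numbers shown in this assay, at 209000 nM. Compound 1 is its nearest neighbour, and compound 2 is known only as a limit (the limit of < 2000 nM in this assay, at which 1 of the 3 values shown sits).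

Compound 4 `CC(Sc1nc2c(cnn2C)c(=O)n1-c1ccccc1)c1cccc(O)c1` differs from compound 3 in one place: 3-hydroxyphenyl in place of pyridin-3-yl on a saturated chain carbon bound to a saturated chain carbon and a sulfur.

The closest measured change is an at least 100-fold higher number from compound 2 to compound 3 (2.01 log units; beyond the scatter), which swaps 3-methoxyphenyl for pyridin-3-yl. Read in reverse, it points to a large fall on leaving pyridin-3-yl. Two further steps, an at least 10-fold lower number from compound 1 to compound 2 (1.00 log units; beyond the scatter) and a 10-fold higher number from compound 1 to compound 3 (1.02 log units; beyond the scatter), run in the same sense. Within the data shown here, no measured compound carries 3-hydroxyphenyl, so the full size of that fall is not assumed.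

A large drop is expected, an estimated 17-fold lower number from compound 3 to compound 4 (1.24 log units; beyond the scatter). Compound 4 is expected at 12000 nM, with an estimated range from 2500 nM to 60000 nM.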

Compound 4, solubility: 21000 nM
The estimate for compound 4 lay 1.8-fold (0.24 log units) below the measured number; the measured number falls inside the stated range.
By their numbers in this assay, from the lowest: compounds 1 and 4 (each within the scatter of the next); then compound 3. At a limit, below all of these: compound 2.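

In this assay, 3-hydroxyphenyl in place of pyridin-3-yl on this saturated chain carbon gives a 10-fold lower number from compound 3 to compound 4 (1.00 log units; beyond the scatter), so the pyridin-3-yl of compound 3 now stands clear of a second group, one with a ring of carbon only. Hydrogen in place of methyl on the oxygen on the aromatic ring gives an at least 10-fold higher number from compound 2 to compound 4 (1.02 log units; beyond the scatter), the first step shown that alters only that oxygen, but compound 2 is a limit of the assay: the limit of < 2000 nM in this assay, at which 1 of the 4 values shown sits. The remaining step, a 1.1-fold higher number from compound 1 to compound 4 (0.02 log units; within the scatter), lies within the scatter, so 3-hydroxyphenyl and pyridin-2-yl cannot be told apart here.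

The compounds shown leave open how a 3-aminophenyl or a 3-carboxyphenyl would stand on this carbon. They also leave open whether the step from pyridin-3-yl to 3-hydroxyphenyl would hold on a longer chain.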